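Furan-3-yl to ethynyl on the methyl compound

The source may report more compounds than this note shows. Statements on the series, on what has been measured and on what is new or still open speak of the compounds shown alone.

Values in a functional assay on CCRF-CEM cells (Homo sapiens), read by MTT assay, with a stated time of 72 h; on this read-out lower numbers stand for stronger inhibition and higher numbers for weaker inhibition:
- compound 1 `CNc1ncnc2c1c(-c1ccoc1)cn2[C@@H]1O[C@H](CO)[C@@H](O)[C@H]1O` gives > 20000 nM (a limit)
- compound 2 `CN(C)c1ncnc2c1c(-c1ccoc1)cn2[C@@H]1O[C@H](CO)[C@@H](O)[C@H]1O` gives 13300 nM
- compound 3 `Cc1ncnc2c1c(-c1ccoc1)cn2[C@@H]1O[C@H](CO)[C@@H](O)[C@H]1O` gives > 20000 nM (a limit)

Compound 3 has no number, only a limit: the limit of > 20000 nM in this assay, at which 2 of the 3 values shown sit. The change to compound 4 `C#Cc1cn([C@@H]2O[C@H](CO)[C@@H](O)[C@H]2O)c2ncnc(C)c12` is ethynyl in place of furan-3-yl on an aromatic carbon. The measured steps are small or unreadable: an at least 1.5-fold lower number from compound 1 to compound 2 (0.17 log units; that floor lies within the scatter), a step that the two limits leave unreadable from compound 1 to compound 3 and an at least 1.5-fold higher number from compound 2 to compound 3 (0.17 log units; that floor lies within the scatter). All three exchange methylamino, dimethylamino or methyl, and none touches the furan-3-yl, so they set no size for this change. With compound 3 at a limit, any readable number in this assay would be lower, and a wide range is kept. The expected step is an at least 4.0-fold lower number from compound 3 to compound 4 (0.60 log units; beyond the scatter). For compound 4 the estimated value is 5000 nM, with an expected range from 400 nM to 20000 nM.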

Compound 4, half-maximal inhibitory concentration: 5600 nM
Beside the measured number, compound 4's estimate is 1.1-fold (0.05 log units) below it, and the stated range covers the measured number.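

In this assay, for the compounds shown here, ethynyl in place of furan-3-yl gives an at least 3.5-fold lower number from compound 3 to compound 4 (0.55 log units; beyond the scatter), the first step that lies beyond the scatter. Activity therefore responds to the group on this aromatic carbon, which the methylamino, dimethylamino and methyl exchanges could not show. Compound 3 has only a limit, so the size of this step is a floor: the limit of > 20000 nM in this assay, at which 2 of the 4 values shown sit.

The compounds shown do not separate the loss of the furan-3-yl ring from the arrival of the triple bond; an ethyl or phenyl group on this carbon would bear on that. From the compounds shown here alone, whether ethynyl behaves the same alongside methylamino or dimethylamino also stays open.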